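This account rests on a few compounds, and the source may have more. Where it says the series, first, only, none or still open, it means among the compounds named here.

Compound 1 `Brc1ccc(/C=N/c2nnc(SCc3c[se]c(-c4ccccc4)n3)s2)cc1` — 46500 nM in a functional assay on L1210 cells (Mus musculus) for antiproliferative activity, read by CCK-8 assay; a lower number here means a stronger inhibitor, a higher number a weaker inhibitor
Compound 2 `COc1cc(/C=N/c2nnc(SCc3c[se]c(-c4ccccc4)n3)s2)ccc1O` — > 100000 nM in this assay

Compound 1 gives 46500 nM in this assay. For compound 2 the assay reports only a limit and no number, namely (the limit of > 100000 nM in this assay, at which 1 of the 2 values shown sits). Among the compounds with values here, compound 2 therefore sits at the weak end of what can be reported, and the one measured step, an at least 2.1-fold higher number from compound 1 to compound 2 (0.33 log units; beyond the scatter), runs toward weaker inhibition.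

Compound 3 `Cc1ccc(/C=N/c2nnc(SCc3c[se]c(-c4ccccc4)n3)s2)cc1` is not yet measured. It differs from compound 2 by 4-methylphenyl in place of 4-hydroxy-3-methoxyphenyl on a carbon with a double bond to nitrogen. Within the data shown here, the only measured step bears on it directly: going from compound 1 to compound 2 put the 4-hydroxy-3-methoxyphenyl in place of a 4-bromophenyl and weakened inhibition, and the step to compound 3 takes that same group out again, putting in a 4-methylphenyl that, like the 4-bromophenyl, carries no hydroxyl or methoxy. The weakening is therefore expected to be undone at least in part, giving a step toward a lower number. Compound 3 is expected to give about 50000 nM in this assay, within 20000 nM to 150000 nM, meaning an expected step of an at least 2.0-fold lower number from compound 2 to compound 3 (0.30 log units; that floor lies within the scatter).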

Compound 3, half-maximal inhibitory concentration: 58600 nM
Estimate against measurement, compound 3: 1.2-fold (0.07 log units) below; measured number inside the range.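

The 4-methylphenyl and the 4-bromophenyl cannot be told apart in this assay, as the printed step shows a 1.3-fold higher number from compound 1 to compound 3 (0.10 log units; within the scatter). So at this position, two aromatic groups without hydroxyl or methoxy give values within the scatter of each other, which a single compound could not show. Replacing the 4-hydroxy-3-methoxyphenyl gives an at least 1.7-fold lower number from compound 2 to compound 3 (0.23 log units; that floor lies within the scatter), so the size of this step remains uncertain, and the value for compound 2 is a limit and not a number: the limit of > 100000 nM in this assay, at which 1 of the 3 values shown sits.

The compounds shown leave open whether the hydroxyl, the methoxy or the two together go with the weaker result for compound 2. They also leave open how a phenyl ring carrying an amine or a carboxylic acid would read in this assay.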